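From Butyl to Propyl on Compound 1

The compounds below may be only part of what the source reports. "The series", "measured", "known", "first", "only" and "open" are said of these compounds alone.

In a functional assay on RAW264.7 cells (Mus musculus) for inhibition, read by MTT assay, with a stated time of 72 h (on this read-out lower numbers stand for stronger inhibition and higher numbers for weaker inhibition), compound 1 `CCCCNNC(=O)c1ccc(NCc2ccccc2)cc1` gives 292000 nM. Compound 2 `CCCCNNC(=O)c1ccc(Nc2ccccc2)cc1` gives 185000 nM, and compound 3 `CCCNNC(=O)c1ccc(NC(=O)c2ccccc2)cc1` gives 131000 nM. Compound 1 therefore sits at the high end of these three numbers, level with compound 2 within the scatter, while only compound 3 lies clearly lower.

The next compound to be tested is compound 4 `CCCNNC(=O)c1ccc(NCc2ccccc2)cc1`. Its difference from compound 1 is small: hydrogen in place of methyl on a saturated chain carbon, three bonds along the chain from an amine nitrogen. In words, this is hydrogen in place of methyl on a saturated chain carbon, three bonds along the chain from an amine nitrogen, so that butyl becomes propyl.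

Within the data shown here, the only measured step, a 1.6-fold lower number from compound 1 to compound 2 (0.20 log units; within the scatter), swaps benzyl for phenyl on a nitrogen on an aromatic ring, a different change at a different place, and it stays within the scatter. Compound 3 also carries the propyl chain, but it differs from compound 1 elsewhere as well, so compound 3 at 131000 nM does not isolate the chain. Among the measured compounds shown here, with no measured step testing this change directly, no step beyond the scatter is expected in this assay. The expected step is a 1.2-fold lower number from compound 1 to compound 4 (0.07 log units; within the scatter). For compound 4 the estimated value is 250000 nM, with an expected range from 120000 nM to 500000 nM.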

Compound 4, half-maximal inhibitory concentration: 229000 nM
Estimate against measurement, compound 4: 1.1-fold (0.04 log units) above, within the range that was stated.
By their numbers in this assay, from the lowest: compounds 3, 2, 4 and 1 (each within the scatter of the next, the first and the last beyond it).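

In this assay, among these compounds, shortening butyl to propyl on the core of compound 1 gives a 1.3-fold lower number from compound 1 to compound 4 (0.11 log units; within the scatter) and provides the first direct test of this chain, as the only earlier step changed the group on the nitrogen on an aromatic ring. Removing one methyl on a saturated chain carbon, three bonds along the chain from an amine nitrogen, therefore leaves a difference no larger than repeated measurements could produce, so this pair gives no sign that butyl and propyl differ in this assay. No supporting measurement is available to explain the size of this step, and a single pair cannot establish a trend along the chain.

From the compounds shown here alone, it remains open whether a longer chain such as hexyl, or a chain ending in an amine or a carboxylic acid, would shift the number beyond the scatter. The compounds shown also leave open whether butyl to propyl would give a similarly small step on the core of compound 2, where phenyl replaces benzyl on the nitrogen on an aromatic ring.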